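The source may hold more compounds than are shown below. What is called first, only, known or untested is meant among the compounds shown, and "the series" means these compounds.

Measured so far:
compound 1, `COc1cc2c(cc1OC)C(=O)C(CC1CCN(C(=S)Nc3cccc(C)c3)CC1)C2`, 300 mg/kg in a functional assay on the whole organism (strain Swiss albino) with Mus musculus as the target, in the maximal electroshock model, with a stated time of 0.5 h; a higher number here means that more compound is needed for the effect, a lower number that less compound is needed;
compound 2, `COc1cc2c(cc1OC)C(=O)C(CC1CCN(C(=S)Nc3ccc(C)cc3)CC1)C2`, 30 mg/kg in this assay;
compound 3, `COc1cc2c(cc1OC)C(=O)C(CC1CCN(C(=S)Nc3cccc([N+](=O)[O-])c3)CC1)C2`, 300 mg/kg in this assay.

Compound 3 stands level with compound 1 at the digits shown, the two together giving the highest numbers of the three, because no change at the digits printed from compound 1 to compound 3 (within the scatter); compound 2 sits apart, because a 10-fold higher number from compound 2 to compound 3 (1.00 log units; beyond the scatter).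

Compound 4, `COc1cc2c(cc1OC)C(=O)C(CC1CCN(C(=S)Nc3cccc(Cl)c3)CC1)C2`, has not been measured in this assay. It differs from compound 3 as follows: chloro in place of nitro on an aromatic carbon.

Among the compounds with values here, the only step that bears on a change at this position is no change at the digits printed from compound 1 to compound 3 (within the scatter), which did not move the number. Within the data shown here, no step compares chloro with any other group. Compound 4 is therefore expected to give 300 mg/kg in this assay, range 100 mg/kg to 300 mg/kg. The expected step is no change at the digits printed from compound 3 to compound 4 (within the scatter), none beyond the scatter.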

Compound 4, minimum effective dose: 300 mg/kg
For compound 4 middle estimate and measured number coincide at the digits printed; the range from low to high includes it.
By their numbers in this assay, from the lowest: compound 2; then compounds 1, 3 and 4 (each within the scatter of the next).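

Chloro at this place on the aromatic carbon gives no change at the digits printed from compound 3 to compound 4 (within the scatter) and no change at the digits printed from compound 1 to compound 4 (within the scatter) in this assay, so 3-chlorophenyl reads alike with the nitro and methyl analogues. The lower number stays with 4-methylphenyl alone: a 10-fold higher number from compound 2 to compound 4 (1.00 log units; beyond the scatter). No measurement on the compounds accounts for this pattern.

The compounds shown leave open whether the lower number of compound 2 goes with the methyl group or with its place on the ring. Going by these compounds, an amine or a carboxylic acid on this aromatic carbon also remains open.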